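The source may report more compounds than this note shows. Statements on the series, on what has been measured and on what is new or still open speak of the compounds shown alone.

Compound 1 `COc1ccc(/C=N/NC(=O)c2cccc(S(=O)(=O)N3CCOCC3)c2)c(O)c1` gives 5800 nM in a functional assay on PC-3 cells (Homo sapiens) for antiproliferative activity, read by MTT assay, with a stated time of 72 h; a lower number here means a stronger inhibitor, a higher number a weaker inhibitor. Among the compounds with values here, compound 2 `O=C(N/N=C/c1cc(Br)ccc1O)c1cccc(S(=O)(=O)N2CCOCC2)c1` differs from it only on the ring carrying the hydroxy group, and in this assay compound 2 gives 7230 nM; the step of a 1.2-fold higher number from compound 1 to compound 2 (0.10 log units; within the scatter) leaves the two numbers within the scatter of each other, so compound 2 stands level with compound 1 on the two numbers so far. Compound 3 `O=C(N/N=C/c1cc(Br)cc(Br)c1O)c1cccc(S(=O)(=O)N2CCOCC2)c1` is drawn from compound 2 by one change: bromo in place of hydrogen on an aromatic carbon. Within the data shown here, only the step from compound 1 to compound 2 bears on this, and it concerns a different position of the same ring and stayed within the scatter; no measured step shows what a bromo entering beside the hydroxy group does. The expected step from compound 2 to compound 3 in this assay is therefore a 1.0-fold higher number from compound 2 to compound 3 (0.02 log units; within the scatter), nothing beyond the scatter. Compound 3 is estimated at 7500 nM, between 3000 nM and 18000 nM.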

Compound 3, half-maximal inhibitory concentration: 9700 nM
Compound 3: the middle estimate sits 1.3-fold (0.11 log units) below what was measured, and the stated range covers the measured number.
By their numbers in this assay, from the lowest: compounds 1, 2 and 3 (each within the scatter of the next).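

In this assay, within the data shown here, a bromo entering ortho to a hydroxy group and meta to a bromo group gives a 1.3-fold higher number from compound 2 to compound 3 (0.13 log units; within the scatter) and so stays within the scatter, which shows that this position, untouched in the earlier compounds, accepts the added bromo with no clear shift in the number. The wider change to the 3,5-dibromo-2-hydroxyphenyl group gives a 1.7-fold higher number from compound 1 to compound 3 (0.22 log units; within the scatter) and also stays within the scatter, so all three ring patterns remain level in this assay. Nothing available here accounts for this outcome.

What the compounds shown leave open is whether a group other than bromo at this position, such as an amine or a carboxylic acid, would move the number beyond the scatter. They also leave open whether any change away from this ring, elsewhere on the shared core, would do so.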